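Swapping the aryl group on a weakly active core

This account rests on a few compounds, and the source may have more. Where it says the series, first, only, none or still open, it means among the compounds named here.

Three compounds share one core and differ only in the aromatic group attached to a ring nitrogen. Compound 1 `N#CC1=C(N)Oc2c(N)cc3nc4ccccc4nc3c2C12C(=O)N(Cc1cnnn1-c1ccc(Cl)cc1)c1ccccc12` carries a 4-chlorophenyl group, compound 2 `Cc1cc(C)cc(-n2nncc2CN2C(=O)C3(C(C#N)=C(N)Oc4c(N)cc5nc6ccccc6nc5c43)c3ccccc32)c1` a 3,5-dimethylphenyl group, and compound 3 `COc1ccc(OC)c(-n2nncc2CN2C(=O)C3(C(C#N)=C(N)Oc4c(N)cc5nc6ccccc6nc5c43)c3ccccc32)c1` a 2,5-dimethoxyphenyl group. In a functional assay on HepG2 cells (Homo sapiens) for antiproliferative activity, read by MTT assay, with a stated time of 48 h (a lower number here means a stronger inhibitor, a higher number a weaker inhibitor), compound 1 returns only a limit of the assay, > 50000 nM. Compound 2 likewise returns only a limit, > 50000 nM. For the measured compounds named here, compound 3 is the single compound with a number, 45100 nM, so it stands alone among the three, with the limit of > 50000 nM in this assay, at which 2 of the 3 values shown sit, holding the other two. The step of an at least 1.1-fold lower number from compound 1 to compound 3 (0.04 log units; that floor lies within the scatter) and the step of an at least 1.1-fold lower number from compound 2 to compound 3 (0.04 log units; that floor lies within the scatter) both sit at a floor that lies within the scatter, and the step that the two limits leave unreadable from compound 1 to compound 2 cannot be read from two limits. Compound 4 `N#CC1=C(N)Oc2c(N)cc3nc4ccccc4nc3c2C12C(=O)N(Cc1cnnn1-c1c(Cl)cc(Cl)cc1Cl)c1ccccc12` follows with 2,4,6-trichlorophenyl in place of 2,5-dimethoxyphenyl on an aromatic nitrogen. Each earlier aryl swap left the number within the scatter, so the expected step of a 1.1-fold higher number from compound 3 to compound 4 (0.04 log units; within the scatter) is none beyond it. Compound 4 is therefore expected near 50000 nM, between 25000 nM and 120000 nM, and most likely to come back once more as a limit.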

Compound 4, half-maximal inhibitory concentration: 37800 nM
Estimate against measurement, compound 4: 1.3-fold (0.12 log units) above; measured number inside the range.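

For the compounds shown here, the aromatic nitrogen of the five-membered ring now carries two groups with real numbers in this assay, so they can be compared directly for the first time: a 1.2-fold lower number from compound 3 to compound 4 (0.08 log units; within the scatter). Moving from an aryl group bearing oxygen to one bearing only chlorine therefore leaves the result inside the usual scatter. The steps from the two compounds that return only a limit are floors, an at least 1.3-fold lower number from compound 2 to compound 4 (0.12 log units; that floor lies within the scatter) and an at least 1.3-fold lower number from compound 1 to compound 4 (0.12 log units; that floor lies within the scatter), and neither can be read as a real gain: the limit of > 50000 nM in this assay, at which 2 of the 4 values shown sit.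

Still open, on these data alone, is whether any group at this position can move the number beyond the scatter. A cyclohexyl ring, a longer alkyl chain, or a phenyl ring carrying an amine or a carboxylic acid would test this beyond the halogen, methyl and methoxy substituents shown.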